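This account rests on a few compounds, and the source may have more. Where it says the series, first, only, none or still open, it means among the compounds named here.

Compound 3, `COc1cc(-c2nn(-c3cccc(NC(=O)Nc4cccc(C(F)(F)F)c4)c3)cc2-c2ccncc2)ccc1Cl`, gives 714 nM in a functional assay on NCI-H522 cells (Homo sapiens) for inhibition, read by sulforhodamine B assay, with a stated time of 48 h; a lower number here means a stronger inhibitor of growth, a higher number a weaker inhibitor of growth. Among the three measured compounds its number is the lowest, but the gaps to the others are small: compound 2, `COc1cc(-c2nn(-c3cccc(NC(=O)Nc4ccc(Cl)c(Cl)c4)c3)cc2-c2ccncc2)ccc1Cl`, gives 811 nM in this assay, and compound 1, `COc1cc(-c2nn(-c3cccc(NC(=O)c4cccc(C(F)(F)F)c4)c3)cc2-c2ccncc2)ccc1Cl`, gives 1050 nM in this assay, so none of the three can be set apart from the others.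

Compound 4, `COc1cc(-c2nn(-c3cccc(NC(=O)c4ccc(Cl)c(C(F)(F)F)c4)c3)cc2-c2ccncc2)ccc1Cl`, carries the change (4-chloro-3-(trifluoromethyl)phenyl in place of (3-(trifluoromethyl)phenyl)amino on a carbonyl carbon). For the measured compounds named here, the step that bears most directly on it is the one from compound 1 to compound 3, where an arylamino entered in place of an aryl on the carbonyl carbon and the number moved by a 1.5-fold lower number from compound 1 to compound 3 (0.17 log units; within the scatter). The step from compound 1 to compound 2, a 1.3-fold lower number from compound 1 to compound 2 (0.11 log units; within the scatter), is of the same kind and likewise stayed within the scatter. Going by the values given here, compound 4 reverses that kind of change, now with a 4-chloro-3-(trifluoromethyl)phenyl on the carbonyl carbon; there is no measured step showing the effect of the added chlorine. Since the earlier step from compound 1 to compound 3 stayed within the scatter, compound 4 is expected to sit close to compound 3, with a step of about a 1.3-fold higher number from compound 3 to compound 4 (0.12 log units; within the scatter). The estimate for compound 4 in this assay is 950 nM, with a range from 500 nM to 1800 nM.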

Compound 4, concentration for 50% growth inhibition: 1040 nM
The estimate for compound 4 lay 1.1-fold (0.04 log units) below the measured number, and the stated range covers the measured number.
By their numbers in this assay, from the lowest: compounds 3, 2, 4 and 1 (each within the scatter of the next).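

In this assay, for the compounds shown here, chloro in place of hydrogen on an aromatic carbon reads as a 1.0-fold lower number from compound 1 to compound 4 (0.00 log units; within the scatter) and so offers the first direct look at that change, which leaves the 4-chloro-3-(trifluoromethyl)phenyl on the carbonyl carbon indistinguishable from the 3-(trifluoromethyl)phenyl of compound 1. Set against the arylamino groups on the same carbonyl carbon, the new group reads as a 1.5-fold higher number from compound 3 to compound 4 (0.16 log units; within the scatter) and as a 1.3-fold higher number from compound 2 to compound 4 (0.11 log units; within the scatter), so the loss of the hydrogen-bond donor counted in the leaving group shows no effect that can be told from the scatter in either step. No measurement is available that would explain why these four compounds read so much alike.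

The compounds shown leave open whether something other than an aryl or arylamino group on this carbonyl carbon, such as a morpholine, a carboxylic acid or a longer alkyl chain, would move the number beyond the scatter. They also leave open whether a bromo or a methyl in place of the added chloro would read any differently from the chloro.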